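The source may report more compounds than this note shows. Statements on the series, on what has been measured and on what is new or still open speak of the compounds shown alone.

In an ADME assay on microsomes from liver (Homo sapiens) for metabolic stability, read by mass spectrometry, using NADPH, tested at 1.5 uM (on this read-out lower numbers stand for a shorter-lived compound and higher numbers for a longer-lived compound), compound 1 `O=C(Nc1ccc2sc(-c3ccccc3)nc2c1)N1CCCCC1` reads > 1 h, which is a limit of the assay. Within the data shown here, compound 2 `O=C(Nc1ccc2sc(-c3ccccc3)nc2c1)N1CCCC1` gives 0.5 h, the only exact number available. Among the measured compounds shown here, the one measured step is an at least 2.0-fold lower number from compound 1 to compound 2 (0.30 log units; that floor lies within the scatter), with pyrrolidin-1-yl in place of piperidin-1-yl on a carbonyl carbon. Compound 3 `O=C(Nc1ccc2sc(-c3ccccc3)nc2c1)c1ccccc1` changes that same place, (phenyl in place of pyrrolidin-1-yl on a carbonyl carbon), with phenyl in place of pyrrolidin-1-yl on a carbonyl carbon. That single step involves no phenyl, so it offers little guidance, and nothing beyond the scatter is expected: the estimated change is a 1.2-fold higher number from compound 2 to compound 3 (0.08 log units; within the scatter). For compound 3 the expected half-life is 0.6 h, within an estimated range of 0.25 h to 1.2 h.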

Compound 3, half-life: > 1 h
Compound 3 gave a limit, no number; the forecaster's own chance of this, stated with the estimate: 25%; at least 1.6-fold (0.22 log units) between middle value and limit.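

In this assay, the new result extends this position beyond the two cyclic amines: phenyl on the carbonyl carbon, with no amide-type nitrogen there, gives an at least 2.0-fold higher number from compound 2 to compound 3 (0.30 log units; that floor lies within the scatter). Compound 3 therefore joins compound 1 at a limit of the assay rather than giving a number. The step between these two compounds cannot be read: the limit of > 1 h in this assay, at which 2 of the 3 values shown sit.

On these data alone, how long either compound actually lasts remains open. So does whether morpholin-4-yl or a pyridyl ring on the same carbonyl carbon would also reach that limit.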